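The compounds below may be only part of what the source reports. "The series", "measured", "known", "first", "only" and "open" are said of these compounds alone.

Three compounds share one core and differ only in the group on the amide nitrogen. Compound 1 `CCCNC(=O)CC1CCc2cc(OC)c(OC)cc21` gives 26.9% in a functional assay on the whole organism (strain Swiss albino) for inhibition, with Mus musculus as the target, in the writhing test, with stated times of 60 min and 15 min, at a dose of 100 mg/kg by the oral route; on this read-out lower numbers stand for less inhibition and higher numbers for more inhibition at the one dose given (going by the name of the read-out). Compound 2 `COc1cc2c(cc1OC)C(CC(=O)NC(C)(C)C)CC2` gives 41.8%, and compound 3 `COc1cc2c(cc1OC)C(CC(=O)NC1CCCC1)CC2` gives 37%. Compound 2 stands highest of the three numbers, but its gap to compound 3, a number 4.8 percentage points lower from compound 2 to compound 3 (within the scatter), is within the scatter, so the two are not separated; only compound 1 lies apart, with a number 14.9 percentage points higher from compound 1 to compound 2 (beyond the scatter) and a number 10.1 percentage points higher from compound 1 to compound 3 (beyond the scatter).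

Compound 4 `COc1cc2c(cc1OC)C(CC(=O)N1CCNCC1)CC2` is not yet measured. It differs from compound 2 by piperazin-1-yl in place of (tert-butyl)amino on a carbonyl carbon. The measured steps all exchange one group on the amide-type nitrogen for another and produced modest rises or none; none of them brings in piperazin-1-yl or a ring with a second nitrogen, so they bear on compound 4 only loosely. On that basis compound 4 is expected to stay near compound 2, with a step of a number 5.8 percentage points lower from compound 2 to compound 4 (within the scatter) that need not exceed the scatter. Compound 4 is therefore estimated at 36%, within 20% to 52%.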

Compound 4, a percentage reported as inhibition, in the whole organism at one dose (the size of the read-out at that dose, not a potency): 68.8%
The estimate for compound 4 lay 32.8 percentage points below the measured number; measured number above the stated range.
By their numbers in this assay, from the lowest: compound 1; then compounds 3 and 2 (each within the scatter of the next); then compound 4.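

The earlier steps shown here only exchanged one open or carbocyclic group on the amide-type nitrogen for another, and they showed at most modest changes. Piperazin-1-yl on the same carbonyl carbon shows that this position can carry a much larger change in this assay (steps: a number 27 percentage points higher from compound 2 to compound 4 (beyond the scatter); a number 31.8 percentage points higher from compound 3 to compound 4 (beyond the scatter); a number 41.9 percentage points higher from compound 1 to compound 4 (beyond the scatter)), which places compound 4 highest of the four, beyond the scatter from each of the others. Nothing available accounts for this rise.

The compounds shown do not separate the contribution of the second ring nitrogen from that of the six-membered ring itself, a question that piperidin-1-yl or morpholin-4-yl at this place would address. They also leave open whether a substituent on the free ring nitrogen, such as methyl or acetyl, keeps the higher number.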